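Swapping the aryl on the carbon double-bonded to nitrogen

The source may hold more compounds than are shown below. What is called first, only, known or untested is meant among the compounds shown, and "the series" means these compounds.

Of the compounds shown here, two that share a common core have been measured in a functional assay on CCRF-CEM cells (Homo sapiens) for inhibition, read by sulforhodamine B assay, with a stated time of 48 h; a lower number here means a stronger inhibitor of growth, a higher number a weaker inhibitor of growth. Compound 1 `NS(=O)(=O)c1ccc(Nc2nc(N/N=C/c3ccc(C(F)(F)F)cc3)nc(Nc3ccccc3)n2)cc1` gives 3000 nM. Compound 2 `Cc1nn(-c2ccccc2)cc1/C=N/Nc1nc(Nc2ccccc2)nc(Nc2ccc(S(N)(=O)=O)cc2)n1` gives 2090 nM, the lowest of the two numbers, with compound 1 the nearest at a gap that stays within the scatter. Among the measured compounds shown here, the single step between them, a 1.4-fold lower number from compound 1 to compound 2 (0.16 log units; within the scatter), replaced one aryl group on the carbon with a double bond to nitrogen with another and shifted the number only within the scatter.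

Compound 3 `NS(=O)(=O)c1ccc(Nc2nc(N/N=C/c3ccccn3)nc(Nc3ccccc3)n2)cc1` has not yet been measured. It differs from compound 2 in one place: pyridin-2-yl in place of 3-methyl-1-phenyl-1H-pyrazol-4-yl on a carbon with a double bond to nitrogen. This is a second replacement at the same carbon. For the measured compounds named here, the only measured step that bears on it is a 1.4-fold lower number from compound 1 to compound 2 (0.16 log units; within the scatter), which lay within the scatter, so a further swap at this position is expected to give no step beyond the scatter in this assay. For compound 3 the expected step is accordingly a 1.2-fold higher number from compound 2 to compound 3 (0.08 log units; within the scatter). Compound 3 is therefore estimated to give 2500 nM in this assay, with a range from 1000 nM to 6500 nM.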

Compound 3, concentration for 50% growth inhibition: 310 nM
For compound 3 the middle estimate is 8.1-fold (0.91 log units) above the measured one; the whole stated range lies above it.
By their numbers in this assay, from the lowest: compound 3; then compounds 2 and 1 (each within the scatter of the next).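

At this position the aryl group is not interchangeable in this assay: pyridin-2-yl gives a 6.7-fold lower number from compound 2 to compound 3 (0.83 log units; beyond the scatter) and, against the other aryl group, a 9.7-fold lower number from compound 1 to compound 3 (0.99 log units; beyond the scatter), although the two groups it replaces lie within the scatter of each other. A single six-membered aromatic ring does not account for this on its own, since the 4-(trifluoromethyl)phenyl of compound 1 is also one and compound 1 stays within the scatter of compound 2, so among these three compounds the lower number goes with the six-membered aromatic ring that carries a hetero atom, seen in compound 3 alone. No measurement is available that would explain this step.

The compounds shown leave open whether an unsubstituted phenyl on this carbon would fall with compound 3 or with compound 1 and compound 2, and so whether the ring nitrogen of pyridin-2-yl matters at all. They also leave open whether pyridin-3-yl or pyridin-4-yl would keep the lower number, and whether an amine or a methoxy group on the pyridine ring would be tolerated.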